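Fixing the stereochemistry of a cyclopropane-linked bile acid receptor agonist

The source may hold more compounds than are shown below. What is called first, only, known or untested is meant among the compounds shown, and "the series" means these compounds.

In an assay on isolated protein for agonist activity at Bile acid receptor (Homo sapiens), read by FRET (a higher number here means a larger maximal response, a lower number a smaller maximal response), compound 1 `O=C(O)c1cncc(N2CC(O)(c3ccc(OCc4c(-c5c(Cl)cccc5Cl)noc4C4CC4)cc3Cl)C2)c1` gives 102% and compound 2 `O=C(O)c1cccc(C2CC2c2ccc(OCc3c(-c4c(Cl)cccc4Cl)noc3C3CC3)cc2Cl)c1` gives 102%, the two standing level and together the highest of the three measured values. Compound 3 `Clc1cc(OCc2c(-c3c(Cl)cccc3Cl)noc2C2CC2)ccc1C1CC1c1ccc(-c2nnn[nH]2)nc1` gives 101%, and the step of a number 1 percentage points lower from compound 2 to compound 3 (within the scatter) stays within the scatter. Compound 4 `O=C(O)c1cccc([C@H]2C[C@@H]2c2ccc(OCc3c(-c4c(Cl)cccc4Cl)noc3C3CC3)cc2Cl)c1` differs from compound 2 as follows: the two compounds have the same atoms and bonds; at least one stereo element is drawn with a configuration in one of them and without one in the other: 2 of 2 stereo elements differ; a stereocentre at a saturated ring carbon is drawn without a configuration in compound 2 and S in compound 4; a stereocentre at a saturated ring carbon is drawn without a configuration in compound 2 and S in compound 4. Within the data shown here, no measured step changes a stereo element alone, so the only guide is that compound 2 already sits at a full response and the one measured step from it was small. The expected step of a number 2 percentage points lower from compound 2 to compound 4 (within the scatter) is therefore none beyond the scatter. Compound 4 is estimated at 100%, within a range from 88% to 112%.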

Compound 4, largest response reached (reported as efficacy), in percent of the reference or control that the assay uses: 101%
Beside the measured number, compound 4's estimate is 1 percentage points below it; the measured number falls inside the stated range.
By their numbers in this assay, from the lowest: compounds 3, 4, 1 and 2 (each within the scatter of the next).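

Earlier compounds changed only the group on the saturated ring carbon, whereas this pair tests the configuration of the ring itself. In this assay, fixing both saturated ring carbons as S gives a number 1 percentage points lower from compound 2 to compound 4 (within the scatter), so compound 4 holds the response of compound 2. The comparison is not one between two single stereoisomers, since the makeup of compound 2 at these carbons is not given: the fact that one of compounds 2 and 4 is drawn with a defined configuration and the other without, at the place where they differ

Going by these compounds, whether other configurations at these two carbons hold the response remains open. So does whether a sulfonamide in place of the carboxylic acid of compound 4 would do so.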